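The compounds below may be only part of what the source reports. "The series", "measured", "known", "first", "only" and "open" are said of these compounds alone.

Compound 2 `Cc1ccc(Cn2sc3ncccc3c2=O)cc1` has been measured in an assay for inhibition of histone acetyltransferase KAT2B (Homo sapiens), read by fluorescence; on this read-out higher numbers stand for weaker inhibition and lower numbers for stronger inhibition. In this assay compound 2 gives 27900 nM. Its nearest companion is compound 1 `O=c1c2cccnc2sn1Cc1ccccc1`, which in this assay gives 23000 nM; the two numbers lie within the scatter of each other. Among the measured compounds shown here, the single measured step, a 1.2-fold higher number from compound 1 to compound 2 (0.08 log units; within the scatter), is the only guide to the next change. Compound 3 `O=c1c2cccnc2sn1Cc1ccc(F)cc1` carries fluoro in place of methyl on an aromatic carbon. Because a 1.2-fold higher number from compound 1 to compound 2 (0.08 log units; within the scatter) stayed within the scatter, the fluoro is expected to behave much the same, with an estimated step of a 1.1-fold lower number from compound 2 to compound 3 (0.05 log units; within the scatter). Compound 3 is accordingly expected to give about 25000 nM, between 10000 nM and 60000 nM.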

Compound 3, half-maximal inhibitory concentration: 86300 nM
For compound 3 the middle estimate is 3.5-fold (0.54 log units) below the measured one; measured number above the stated range.
By their numbers in this assay, from the lowest: compounds 1 and 2 (each within the scatter of the next); then compound 3.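

In this assay this place on the aromatic ring, para to a large group, proves sensitive to the choice of substituent: fluoro in place of methyl gives a 3.1-fold higher number from compound 2 to compound 3 (0.49 log units; beyond the scatter) and fluoro in place of hydrogen gives a 3.8-fold higher number from compound 1 to compound 3 (0.57 log units; beyond the scatter), although the earlier methyl step stayed within the scatter. Compound 3 is therefore the weakest inhibitor of the three. Nothing among the data shown accounts for this result.

On these data alone, whether a chloro, a methoxy or an amine at this place would track with fluoro or with methyl remains open. So does whether a longer chain would leave the number near that of compound 2.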